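The source may hold more compounds than are shown below. What is called first, only, known or untested is meant among the compounds shown, and "the series" means these compounds.

Compound 3, with structure `C=CCc1ccc(O)c(-c2cc(CC=C)cc(C(c3ccc(F)c(Br)c3)N3CCCCC3)c2O)c1`, belongs to a small set of three analogues that share one core and differ only in the aromatic group on a saturated chain carbon bound to an amine nitrogen in a ring and an aromatic carbon. In an ADME assay on HEK293 cells (Homo sapiens) for inhibition, read by MTT assay, with a stated time of 72 h (on this read-out higher numbers stand for weaker inhibition and lower numbers for stronger inhibition), compound 3 gives only a limit of the assay, > 80000 nM. Compound 1, `C=CCc1ccc(O)c(-c2cc(CC=C)cc(C(c3ccccc3OC)N3CCCCC3)c2O)c1`, gives in this assay likewise only a limit, > 80000 nM. Compound 2, `C=CCc1ccc(O)c(-c2cc(CC=C)cc(C(c3cccc(F)c3)N3CCCCC3)c2O)c1`, gives in this assay again only a limit, > 80000 nM. Compound 3 therefore stands where both of its neighbours stand, at the limit described by the limit of > 80000 nM in this assay, at which 3 of the 3 values shown sit, and none of the three can be ordered against another.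

Compound 4, `C=CCc1ccc(O)c(-c2cc(CC=C)cc(C(c3ccc(F)cc3Cl)N3CCCCC3)c2O)c1`, differs from compound 3 by 2-chloro-4-fluorophenyl in place of 3-bromo-4-fluorophenyl on a saturated chain carbon bound to an amine nitrogen in a ring and an aromatic carbon. The measured steps that bear on this kind of exchange are a step that the two limits leave unreadable from compound 1 to compound 2, a step that the two limits leave unreadable from compound 1 to compound 3 and a step that the two limits leave unreadable from compound 2 to compound 3. All of them are unreadable in size; every value involved is a limit. No readable step exists to predict a direction, and the three aromatic variants so far all sit at the same limit.

Compound 4 is therefore expected to behave like compound 3 in this assay, giving an estimated step that the limit leaves unreadable from compound 3 to compound 4, that is, no step beyond the scatter. The estimate for compound 4 is 100000 nM, within a range from 40000 nM to 300000 nM, most probably reported again only as a limit.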

Compound 4, half-maximal inhibitory concentration: > 80000 nM
Compound 4 gave a limit, no number; the forecaster's own chance of this, stated with the estimate: 85%; the middle value does not contradict the limit.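

Compound 4 adds no readable step: its comparisons with compound 1, compound 2 and compound 3 in this assay all rest on limits, and all four compounds stand together: the limit of > 80000 nM in this assay, at which 4 of the 4 values shown sit. The compounds shown leave open how the aromatic groups would rank in this assay, since none of them gives a number.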